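Chloro to Fluoro Across Two Matched Pairs

The source may report more compounds than this note shows. Statements on the series, on what has been measured and on what is new or still open speak of the compounds shown alone.

Compound 1 `Fc1ccc2nc(NC(=S)Nc3ccc(Cl)cc3)sc2c1` and compound 2 `Fc1ccc(NC(=S)Nc2nc3ccc(F)cc3s2)cc1` differ at one place only. In a functional assay on B16-F10 cells (Mus musculus) for cytotoxicity, read by MTT assay, with a stated time of 48 h (a lower number here means a stronger inhibitor, a higher number a weaker inhibitor), compound 1 gives 48100 nM, and compound 2 gives 47700 nM. The change between them is fluoro in place of chloro on an aromatic carbon, and the step it made was a 1.0-fold lower number from compound 1 to compound 2 (0.00 log units; within the scatter). Compound 3 `Fc1ccc2nc(Nc3nc4ccc(Cl)cc4s3)sc2c1` gives 41900 nM in this assay; the difference between the core of compound 1 and the core of compound 3 is not broken down here. Compound 4 `Fc1ccc2nc(Nc3nc4ccc(F)cc4s3)sc2c1` has not yet been measured in this assay. It carries the same kind of change from compound 3, (fluoro in place of chloro on an aromatic carbon), but the place is not identical: in compound 1 the carbon is para to a large group, whereas in compound 3 the carbon belongs to a ring that is part of a fused or bridged system of two rings, meta to a fused ring and para to a fused ring. Because a 1.0-fold lower number from compound 1 to compound 2 (0.00 log units; within the scatter) was within the scatter, compound 4 is expected to give 42000 nM in this assay, between 21000 nM and 84000 nM, an expected step of a 1.0-fold higher number from compound 3 to compound 4 (0.00 log units; within the scatter).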

Compound 4, half-maximal inhibitory concentration: 47500 nM
Compound 4: the middle estimate sits 1.1-fold (0.05 log units) below what was measured; measured number inside the range.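

In this assay, putting fluoro in place of chloro on the second core gave a 1.1-fold higher number from compound 3 to compound 4 (0.05 log units; within the scatter). Set beside the earlier step, the change carried from one core to the other with no difference that can be told from scatter: the same change on two cores in this assay, a 1.0-fold lower number (0.00 log units; within the scatter) from compound 1 to compound 2 and a 1.1-fold higher number (0.05 log units; within the scatter) from compound 3 to compound 4, 1.1-fold (0.06 log units) apart, within the scatter of two such steps. This shows that the swap left the number essentially unmoved at both places, but it does not show that the swap would behave the same way on any other core or at any other ring position.

From the compounds shown here alone, only chloro and fluoro appear at these places, so the effect of a larger or different group there, such as a methoxy group, a nitrile or an amine, remains open. The difference between the core of compound 1 and the core of compound 3 also remains unresolved.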